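The source may hold more compounds than are shown below. What is called first, only, known or untested is meant among the compounds shown, and "the series" means these compounds.

Series notes. The shared core of compound 1 `O/N=C(\CCN1CCN(c2ccccn2)CC1)c1cccc(F)c1` is kept throughout; compound 2 `O/N=C(\CCN1CCN(c2ccccn2)CC1)c1cccc(Cl)c1` carries chloro and compound 3 `Cc1cccc(/C(CCN2CCN(c3ccccn3)CC2)=N/O)c1` carries methyl in place of the fluoro on an aromatic carbon. In a functional assay on HEK293 cells with D(4) dopamine receptor (Homo sapiens) as the target, read by FLIPR (a higher number here means that more compound is needed for the effect, a lower number that less compound is needed), compound 1 gives 17.1 nM, compound 2 gives 11.9 nM and compound 3 gives 2.3 nM. The step of a 1.4-fold lower number from compound 1 to compound 2 (0.16 log units; within the scatter) stays inside the scatter, whereas a 7.4-fold lower number from compound 1 to compound 3 (0.87 log units; beyond the scatter) and a 5.2-fold lower number from compound 2 to compound 3 (0.71 log units; beyond the scatter) lie beyond it, so compound 3 stands lowest of the three numbers, clear of both of the others.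

Compound 4 `O/N=C(\CCN1CCN(c2ccccn2)CC1)c1ccc(Cl)cc1` is not yet measured. Its change from compound 3 is 4-chlorophenyl in place of 3-methylphenyl on a carbon with a double bond to nitrogen. Two parts of this change matter. The exchange of methyl for chloro on the aromatic ring has a direct precedent in a 5.2-fold lower number from compound 2 to compound 3 (0.71 log units; beyond the scatter); read in reverse, it points to a higher number of roughly that size for compound 4. Among the measured compounds shown here, none of the measured steps compares a 3-chlorophenyl with a 4-chlorophenyl, so that part of the change has no precedent in this set and widens the uncertainty. The expected step is therefore a 6.1-fold higher number from compound 3 to compound 4 (0.78 log units; beyond the scatter), a modest rise in this assay. Compound 4 is estimated at 14 nM in this assay, with a range from 4 nM to 60 nM.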

Compound 4, half-maximal effective concentration: 475 nM
For compound 4 the middle estimate is 34-fold (1.53 log units) below the measured one, outside the stated range (above it).
By their numbers in this assay, from the lowest: compound 3; then compounds 2 and 1 (each within the scatter of the next); then compound 4.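

In this assay, where the substituent sits on the ring now counts for far more than which substituent it is: with chloro kept, the exchange of 3-chlorophenyl for 4-chlorophenyl gives a 40-fold higher number from compound 2 to compound 4 (1.60 log units; beyond the scatter) and so exceeds every exchange among the three earlier rings. Among the compounds shown here, the rise appears from each of those rings, with a 28-fold higher number from compound 1 to compound 4 (1.44 log units; beyond the scatter) from the 3-fluorophenyl ring and a 210-fold higher number from compound 3 to compound 4 (2.31 log units; beyond the scatter) from the 3-methylphenyl ring, the largest step in the set, so the earlier compounds, which gave no view of this ring place, did not foretell it. Nothing at hand gives a cause for the size of these steps.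

Open, from the compounds shown here alone, is whether the rise belongs to chloro alone or to any group at this ring place, a question that a 4-methylphenyl or 4-fluorophenyl ring would address directly. Also open, going by these compounds, is how an unsubstituted phenyl or a 3-methoxyphenyl ring would compare in this assay with compound 3 at 2.3 nM, the lowest number of the series.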